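A few compounds are considered here, and "the series" means these few. Any claim that something is new, unique, unknown or untested is made for them only; others in the source may bear on it.

Measured compounds:
Compound 1 `C[C@@H](CNc1ccc(OC(F)(F)F)cc1)NC(=O)[C@H](CCC1CCCCC1)CC(=O)N1CCOCC1` — 95 nM
Compound 2 `O=C(N[C@@H](CCc1ccccc1)CNc1ccc(OC(F)(F)F)cc1)[C@@H](CC(=O)N1CCOCC1)CC1CCCCC1` — 18 nM

In an assay on isolated protein for inhibition of cathepsin S (Homo sapiens) (on this read-out higher numbers stand for weaker inhibition and lower numbers for stronger inhibition), compound 1 gives 95 nM, the higher of the two numbers recorded. Compound 2, which shares the morpholine amide and the trifluoromethoxyphenyl amine but carries a different substituent on the amine-bearing carbon and a cyclohexylmethyl group at the chain position, gives 18 nM in this assay, a lower number, and the gap between the two lies beyond the usual scatter. Going by the values given here, no single-point step between measured compounds is available, so the effect of altering the chain substituent alone is unknown.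

Compound 3 `C[C@@H](CNc1ccc(OC(F)(F)F)cc1)NC(=O)[C@H](CCC(C)(C)C)CC(=O)N1CCOCC1` arises from compound 1 by tert-butyl in place of cyclohexyl on a saturated chain carbon, three bonds along the chain from a carbonyl carbon. For this change a small step is expected, most likely towards a somewhat higher number, and it may well fall within the scatter. Compound 3 is therefore estimated to give 150 nM in this assay, within 50 nM to 500 nM, a step of a 1.6-fold higher number from compound 1 to compound 3 (0.20 log units; within the scatter) from compound 1.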

Compound 3, inhibition constant: 70 nM
Compound 3: the middle estimate sits 2.1-fold (0.33 log units) above what was measured; measured number inside the range.
By their numbers in this assay, from the lowest: compound 2; then compounds 3 and 1 (each within the scatter of the next).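

In this assay, tert-butyl in place of cyclohexyl on a saturated chain carbon, three bonds along the chain from a carbonyl carbon, gives a 1.4-fold lower number from compound 1 to compound 3 (0.13 log units; within the scatter). Going by these compounds alone, this is the first comparison at this position that differs in one place, which compound 1 and compound 2 could not provide, and it shows that the six-membered ring of carbon can give way to a group with no ring and 4 heavy atoms rather than 6 without the read-out leaving the scatter. No measurement at hand speaks to what lies behind this result.

Going by these compounds, it remains open whether an amine, a carboxylic acid or a longer chain in place of tert-butyl on this chain carbon would keep the read-out within the scatter. Also open, on these data alone, is whether neopentyl in place of the cyclohexylmethyl of compound 2 would do the same.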